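The source may hold more compounds than are shown below. What is called first, only, known or untested is meant among the compounds shown, and "the series" means these compounds.

Three compounds have numbers so far in a functional assay on T98G cells (Homo sapiens) for cytotoxicity, read by MTT assay (a lower number here means a stronger inhibitor, a higher number a weaker inhibitor), for now:

- compound 1 `Oc1ccc(CN(Cc2ccccc2)Cc2ccc(O)c3ncccc23)c2cccnc12` gives 249 nM
- compound 2 `Oc1ccc(CN(Cc2cccc(C(F)(F)F)c2)Cc2ccc(O)c3ncccc23)c2cccnc12` gives 57 nM
- compound 3 `Oc1ccc(CN(Cc2cc(C(F)(F)F)cc(C(F)(F)F)c2)Cc2ccc(O)c3ncccc23)c2cccnc12` gives 72 nM

Compound 2 belongs to the low end of these numbers. The measured steps that touch it are a 4.4-fold lower number from compound 1 to compound 2 (0.64 log units; beyond the scatter) and a 1.3-fold higher number from compound 2 to compound 3 (0.10 log units; within the scatter), so only the first of them stands clear of the scatter.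

The unmeasured compound 4 `O=C(O)C1CCC(CN(Cc2ccc(O)c3ncccc23)Cc2ccc(O)c3ncccc23)CC1` alters one arm of compound 2: 4-carboxycyclohexyl in place of 3-(trifluoromethyl)phenyl on a saturated chain carbon bound to an amine nitrogen. That puts 4-carboxycyclohexyl in place of 3-(trifluoromethyl)phenyl on a saturated chain carbon bound to an amine nitrogen.

The closest guide is a 4.4-fold lower number from compound 1 to compound 2 (0.64 log units; beyond the scatter), which shows that this arm can move the number when trifluoromethyl is added. Compound 4 has no trifluoromethyl, so that gain is expected to be lost. For the measured compounds named here, no measured compound carries a carboxy group or a non-aromatic ring on this arm, which leaves the size of the step loosely fixed.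

In this assay the expected change is an 11-fold higher number from compound 2 to compound 4 (1.02 log units; beyond the scatter), a rise beyond the scatter. The estimate for compound 4 is 600 nM, with an expected range of 150 nM to 3000 nM as its spread.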

Compound 4, half-maximal inhibitory concentration: 9760 nM
For compound 4 the middle estimate is 16-fold (1.21 log units) below the measured one; the measured number lies above the stated range.
By their numbers in this assay, from the lowest: compounds 2 and 3 (each within the scatter of the next); then compound 1; then compound 4.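

In this assay, for the compounds shown here, this arm proves far less forgiving than the earlier compounds could show, since they only varied trifluoromethyl groups on a phenyl ring, whereas replacing the whole ring gives a 170-fold higher number from compound 2 to compound 4 (2.23 log units; beyond the scatter) in a single change. Compound 4 also stands well above the plain phenyl arm, with a 39-fold higher number from compound 1 to compound 4 (1.59 log units; beyond the scatter) on that comparison, so the loss goes beyond giving up the gain seen with trifluoromethyl. No measurement at hand explains why this change costs so much.

The change swaps an aromatic ring for a non-aromatic one and adds a carboxy group in one move, so the compounds shown leave open which of the two matters more. A plain cyclohexyl arm and a phenyl arm carrying a carboxylic acid would separate these two changes.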